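Swapping Bromo for Methyl on the Aryl Group

The source may hold more compounds than are shown below. What is called first, only, known or untested is meant among the compounds shown, and "the series" means these compounds.

Measured so far:
compound 1, `CC(c1ccc(-c2ccccc2)c(F)c1)c1nnc2n1N=C(c1ccc(Cl)cc1Cl)CS2`: 7600 nM
compound 2, `CC(c1ccc(-c2ccccc2)c(F)c1)c1nnc2n1N=C(c1ccc(Br)cc1)CS2`: 7400 nM

In a functional assay on MCF7 cells (Homo sapiens) for inhibition, read by sulforhodamine B assay, with a stated time of 72 h (a higher number here means a weaker inhibitor, a lower number a stronger inhibitor), compound 2 gives 7400 nM and compound 1 gives 7600 nM, so the two numbers sit together, and neither can be called the stronger inhibitor. Among the compounds with values here, the one step between them, a 1.0-fold lower number from compound 1 to compound 2 (0.01 log units; within the scatter), shows that changing the aryl group on the carbon with a double bond to nitrogen left the result unchanged.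

Compound 3, `Cc1ccc(C2=Nn3c(nnc3C(C)c3ccc(-c4ccccc4)c(F)c3)SC2)cc1`, is the next compound in this series and has not yet been measured. It differs from compound 2 in one place: methyl in place of bromo on an aromatic carbon. Within the data shown here, the only step known so far, from compound 1 to compound 2, also altered this same aryl group and stayed within the scatter, which gives no reason to expect a shift of any size here. Among the measured compounds shown here, there is, however, no measured example of a bromo-to-methyl swap, so the expectation rests on a single comparison.

Compound 3 is therefore expected to give about 7500 nM in this assay, within a range of 3000 nM to 20000 nM. That estimate corresponds to an expected step of a 1.0-fold higher number from compound 2 to compound 3 (0.01 log units; within the scatter).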

Compound 3, half-maximal inhibitory concentration: 5000 nM
Estimate against measurement, compound 3: 1.5-fold (0.18 log units) above; the range from low to high includes it.
By their numbers in this assay, from the lowest: compounds 3, 2 and 1 (each within the scatter of the next).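

In this assay, methyl can stand in the place of bromo on this aromatic carbon, para to a large group, without moving the result beyond the scatter: the step is a 1.5-fold lower number from compound 2 to compound 3 (0.17 log units; within the scatter). Until now, this position had been explored only by comparing 2,4-dichlorophenyl with 4-bromophenyl, and this change puts a carbon group where a halogen stood, while the heavy-atom count stays the same and no hydrogen-bond donor or acceptor enters. The wider comparison, a 1.5-fold lower number from compound 1 to compound 3 (0.18 log units; within the scatter), also stays within the scatter, so 4-methylphenyl, 4-bromophenyl and 2,4-dichlorophenyl sit together and none can be called the stronger inhibitor, though no measurement at hand explains this likeness.

The three aryl groups shown leave open whether the number would stay in the same place with a very different group at this position, such as an amine, a carboxylic acid or a longer chain like butyl. They also leave open whether any change on the aryl group can move the result beyond the scatter, or whether a change elsewhere on the shared core would be needed.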